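A Second Hydroxy Group on the Side Chain

The source may report more compounds than this note shows. Statements on the series, on what has been measured and on what is new or still open speak of the compounds shown alone.

Compound 1 `CCCn1cnc2ncnc(N)c21` and compound 2 `Nc1ncnc2ncn(CCCO)c12` share a core that differs from that of compound 3 `CC(O)Cn1c(Br)nc2c(N)ncnc21` in a way not broken down here. In an assay on CHO cells for displacement of a labelled ligand from adenosine receptor A1 (Homo sapiens) (a higher number here means a weaker inhibitor, a lower number a stronger inhibitor), compound 1 gives > 100000 nM, which is a limit of the assay rather than a number. Compound 2 likewise gives > 100000 nM in this assay, again a limit. The change between them, (hydroxy in place of hydrogen on a saturated chain carbon, three bonds along the chain from an aromatic nitrogen), thus made a step that the two limits leave unreadable from compound 1 to compound 2; the limit of > 100000 nM in this assay, at which 2 of the 3 values shown sit, covers both. Among the compounds with values here, compound 3 gives 2900 nM in this assay, the only number among the three. Compound 4 `Nc1ncnc2c1nc(Br)n2CC(O)CO` has not been measured; it differs from compound 3 by hydroxy in place of hydrogen on a saturated chain carbon, two bonds along the chain from an oxygen on a saturated carbon, the same kind of change as from compound 1 to compound 2, though the place differs: there the carbon lay three bonds along the chain from an aromatic nitrogen, here two bonds along the chain from an oxygen on a saturated carbon. The earlier step has no readable size, so the expectation rests on compound 3 alone, at 2900 nM. Compound 4 is expected to give 4000 nM, between 1000 nM and 20000 nM, a step of a 1.4-fold higher number from compound 3 to compound 4 (0.14 log units; within the scatter) in this assay.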

Compound 4, inhibition constant: 16000 nM
For compound 4 the middle estimate is 4.0-fold (0.60 log units) below the measured one, within the range that was stated.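

On the core of compound 3, hydroxy in place of hydrogen, here 2-hydroxypropyl to 2,3-dihydroxypropyl, gives a 5.5-fold higher number from compound 3 to compound 4 (0.74 log units; beyond the scatter) in this assay. This single pair shows that on this core the added hydroxy goes with a weaker inhibitor; it does not show that the same would hold on the core of compound 1, where the change also sits at a different place on the chain. The step from compound 1 to compound 2 cannot be read, so the two cores offer no pair of sizes to set side by side: the limit of > 100000 nM in this assay, at which 2 of the 4 values shown sit.

The compounds shown leave open whether the result belongs to the hydroxy group itself or would also come with another group at this place on the chain, such as an amine or a carboxylic acid. They also leave open how the 2,3-dihydroxypropyl chain would read on the core of compound 1, and what a longer chain ending in hydroxy would give on the core of compound 3.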